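The source may hold more compounds than are shown below. What is called first, only, known or untested is meant among the compounds shown, and "the series" means these compounds.

Among the measured compounds shown here, in a functional assay on HT-29 cells (Homo sapiens) for cytotoxicity, read by MTT assay, with a stated time of 48 h (a higher number here means a weaker inhibitor, a lower number a stronger inhibitor), compound 1 `CCOC(=O)/C=C/c1ccc2c(c1)C(=O)C(=O)N2Cc1ccc(OC)cc1` gives 60 nM, the lowest of the two numbers so far. For the measured compounds named here, compound 2 `CCCCOC(=O)/C=C/c1ccc2c(c1)C(=O)C(=O)N2Cc1ccc(OC)cc1` gives 420 nM; the only measured step, a 7.0-fold higher number from compound 1 to compound 2 (0.85 log units; beyond the scatter), concerns the ester chain, not the benzyl ring. Compound 3 `CCOC(=O)/C=C/c1ccc2c(c1)C(=O)C(=O)N2Cc1ccc(Br)cc1` differs from compound 1 on that ring: bromo in place of methoxy on an aromatic carbon. Going by the values given here, no measured step bears on this change, so there is no ground to expect a step in this assay beyond the scatter, in either direction. Compound 3 is therefore estimated at 80 nM, between 25 nM and 250 nM, which means an expected step of a 1.3-fold higher number from compound 1 to compound 3 (0.12 log units; within the scatter).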

Compound 3, half-maximal inhibitory concentration: 50 nM
Compound 3: the middle estimate sits 1.6-fold (0.20 log units) above what was measured, within the range that was stated.
By their numbers in this assay, from the lowest: compounds 3 and 1 (each within the scatter of the next); then compound 2.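

In this assay the 4-methoxybenzyl group of compound 1 can be exchanged for 4-bromobenzyl without a step beyond the scatter (a 1.2-fold lower number from compound 1 to compound 3 (0.08 log units; within the scatter)). Unlike the ester chain, where the one earlier step lies beyond the scatter, this ring position so far accepts the loss of the methoxy oxygen, the one hydrogen-bond acceptor counted in the change. Nothing on hand accounts for this result. Open, on these data alone, is whether an amine, a carboxylic acid or a hydroxyl at this place would hold the value as well. Also open, as far as these compounds go, is whether the same exchange on the butyl ester of compound 2 would stay within the scatter.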